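The compounds below may be only part of what the source reports. "The series", "measured", "known", "first", "only" and "open" are said of these compounds alone.

Measured in a functional assay on A549 cells (Homo sapiens) for antiproliferative activity, read by MTT assay, with a stated time of 72 h; a lower number here means a stronger inhibitor, a higher number a weaker inhibitor:
- compound 1 `NC1=NC2(CCOCC2)N(OCCCOc2ccc(F)cc2)C(N)=N1`: 1060 nM
- compound 2 `NC1=NC2(CCOCC2)N(OCCCOc2ccc(Cl)c(Cl)c2)C(N)=N1`: 790 nM

Within the data shown here, compound 2 stands within the scatter of compound 1, the only other measured compound. Compound 3 `NC1=NC2(CCOCC2)N(OCCCOc2ccc(Br)cc2)C(N)=N1` has 4-bromophenyl in place of 3,4-dichlorophenyl on an oxygen on a saturated carbon. One measured step changes this same aryl group, a 1.3-fold lower number from compound 1 to compound 2 (0.13 log units; within the scatter), and it stays within the scatter. No change beyond the scatter is therefore expected in this assay. The expected step is a 1.1-fold higher number from compound 2 to compound 3 (0.06 log units; within the scatter). For compound 3 the estimated value is 900 nM. The expected range runs from 400 nM to 2000 nM.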

Compound 3, half-maximal inhibitory concentration: 280 nM
Compound 3: middle estimate off by 3.2-fold (0.51 log units), on the high side; measured number outside the range, below it.
By their numbers in this assay, from the lowest: compound 3; then compounds 2 and 1 (each within the scatter of the next).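

In this assay the aryl group on an oxygen on a saturated carbon now moves the number beyond the scatter: 4-bromophenyl in place of 3,4-dichlorophenyl gives a 2.8-fold lower number from compound 2 to compound 3 (0.45 log units; beyond the scatter), and bromo in place of fluoro on an aromatic carbon gives a 3.8-fold lower number from compound 1 to compound 3 (0.58 log units; beyond the scatter). Among these compounds, this position therefore responds to the identity of the halogen substitution, which the first pair of compounds did not reveal. Nothing available here accounts for the gain with bromo. Still open, from the compounds shown here alone, is whether 4-chlorophenyl or 4-methoxyphenyl would match 4-bromophenyl. Also open, going by these compounds, is whether a longer chain to the aryl ether keeps this level.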